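The compounds below may be only part of what the source reports. "The series", "measured", "known", "first", "only" and "open" are said of these compounds alone.

Measured so far in a functional assay on HT cells (Homo sapiens) for antiproliferative activity, read by fluorescence, with a stated time of 72 h; on this read-out higher numbers stand for weaker inhibition of growth and lower numbers for stronger inhibition of growth:
compound 1 `CC(C)c1n[nH]c2c(NCc3ccc(-c4ccccn4)cc3)nc(SCC(O)CN)nc12` — 55 nM
compound 2 `CC(C)c1n[nH]c2c(NCc3ccc(-c4ccccn4)cc3)nc(SCC3CNC(=O)O3)nc12` — 80 nM
compound 3 `CC(C)c1n[nH]c2c(NCc3ccc(-c4ccccn4)cc3)nc(SC(CO)C(C)C)nc12` — 980 nM

Compound 3 gives the highest number of the three. Its nearest neighbour is compound 2, reached by a 12-fold higher number from compound 2 to compound 3 (1.09 log units; beyond the scatter); against compound 1 the gap is an 18-fold higher number from compound 1 to compound 3 (1.25 log units; beyond the scatter). Both of these steps exchange the entire group on the sulfur and both lie beyond the scatter. The step of a 1.5-fold higher number from compound 1 to compound 2 (0.16 log units; within the scatter), by contrast, is within the scatter.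

Compound 4 `CCC(CO)Sc1nc(NCc2ccc(-c3ccccn3)cc2)c2[nH]nc(C(C)C)c2n1` differs from compound 3 in one place: hydrogen in place of methyl on a saturated chain carbon bound to two saturated chain carbons. For the measured compounds named here, none of the measured steps bears on this change directly. Each of them swaps the whole sulfur-bound group, whereas here only one carbon leaves a saturated chain carbon bound to two saturated chain carbons, with the hydroxymethyl and the sulfur attachment kept. Going by the values given here, the large steps of an 18-fold higher number from compound 1 to compound 3 (1.25 log units; beyond the scatter) and a 12-fold higher number from compound 2 to compound 3 (1.09 log units; beyond the scatter) are therefore no guide to the size of this one; they show only that compound 3 already sits well above compounds 1 and 2. Among the compounds with values here, with no closer precedent, the expected step of a 1.2-fold lower number from compound 3 to compound 4 (0.06 log units; within the scatter) is none beyond the scatter, and compound 4 is expected to stay near compound 3. The estimate for compound 4 in this assay is 850 nM, with a range from 350 nM to 2000 nM.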

Compound 4, concentration for 50% growth inhibition: 255 nM
The estimate for compound 4 lay 3.3-fold (0.52 log units) above the measured number, outside the stated range (below it).
By their numbers in this assay, from the lowest: compounds 1 and 2 (each within the scatter of the next); then compound 4; then compound 3.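

In this assay, for the compounds shown here, a 3.8-fold lower number from compound 3 to compound 4 (0.58 log units; beyond the scatter) is the first step that changes a single carbon rather than the whole group on the sulfur. It shows that the numbers respond to the loss of one methyl on a saturated chain carbon bound to two saturated chain carbons, with the hydroxymethyl and the sulfur attachment kept. The isopropyl to ethyl change does not close the whole gap, however: a 3.2-fold higher number from compound 2 to compound 4 (0.50 log units; beyond the scatter) and a 4.6-fold higher number from compound 1 to compound 4 (0.67 log units; beyond the scatter) both remain beyond the scatter, so 1-(hydroxymethyl)propyl on the sulfur still stands apart from the groups carried by compound 1 and compound 2. Nothing available on these compounds accounts for the size of the step from the isopropyl to the ethyl form.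

On these data alone, it remains open whether trimming further to a methyl, or extending to a longer chain such as propyl or butyl, would continue this trend or reverse it. Also open, as far as these compounds go, is what the hydroxymethyl contributes: an amine or a carboxylic acid in its place, with the ethyl kept, would read that directly.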